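The source may hold more compounds than are shown below. What is called first, only, known or untested is meant among the compounds shown, and "the series" means these compounds.

Compound 1 `OC[C@H]1O[C@@H](n2cnc3c(NCc4cccc(Br)c4)ncnc32)[C@H](O)[C@@H]1O`: > 166000 nM
Compound 2 `Cc1ccc(CNc2ncnc3c2ncn3[C@@H]2O[C@H](CO)[C@@H](O)[C@H]2O)cc1`: "not determined" (no result reported)

Both compounds were examined in a functional assay on B16 cells (Mus musculus) for antiproliferative activity, with a stated time of 72 h; a higher number here means a weaker inhibitor, a lower number a stronger inhibitor. Compound 2 has no number of its own, so it holds no place on the scale. The only other entry belongs to compound 1 and is a limit, not a number: the limit of > 166000 nM in this assay, at which 1 of the 2 values shown sits. Compound 3 `OC[C@H]1O[C@@H](n2cnc3c(NCc4ccc(Cl)cc4Cl)ncnc32)[C@H](O)[C@@H]1O` differs from compound 2 as follows: 2,4-dichlorophenyl in place of 4-methylphenyl on a saturated chain carbon bound to a nitrogen on an aromatic ring. In this assay, weak activity is expected for compound 3, with no step beyond the usual scatter from the limit of compound 1. The estimated value for compound 3 is 60000 nM, within an expected range of 10000 nM to 166000 nM.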

Compound 3, half-maximal inhibitory concentration: > 166000 nM
Compound 3: a limit, no number; the forecaster's own chance of this, stated with the estimate: 50%; at least 2.7-fold (0.44 log units) between middle value and limit.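

In this assay, within the data shown here, compound 3 gives > 166000 nM, a limit of the same kind as that of compound 1, so no step between compound 1 and compound 3 can be read. The compounds shown leave open whether 3-bromophenyl and 2,4-dichlorophenyl differ at all in this assay, and how compound 2 compares with either.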